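Nitro to amino on the fused ring core

The compounds below may be only part of what the source reports. "The series", "measured", "known", "first", "only" and "open" are said of these compounds alone.

compound 1, `O=[N+]([O-])c1cc(C(F)(F)F)ccc1S(=O)(=O)Nc1ccc(Oc2ccnc3c([N+](=O)[O-])cccc23)cc1`: > 40000 nM
compound 2, `O=C(Nc1cccc(Oc2ccnc3c([N+](=O)[O-])cccc23)c1)c1cc(C(F)(F)F)cc(C(F)(F)F)c1`: > 40000 nM

In a functional assay on PLC-PRF-5 cells (Homo sapiens) for inhibition (on this read-out lower numbers stand for stronger inhibition and higher numbers for weaker inhibition), compound 1 gives > 40000 nM, which is a limit of the assay and not a number. Compound 2 gives > 40000 nM in this assay, again a limit rather than a measured number. Compound 2 therefore stands at the limit of > 40000 nM in this assay, at which 2 of the 2 values shown sit, with no number of its own to rank against. Among the measured compounds shown here, no pair of measured compounds differs in a single place, so no step size has been measured.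

Compound 3, `Nc1cccc2c(Oc3cccc(NC(=O)c4cc(C(F)(F)F)cc(C(F)(F)F)c4)c3)ccnc12`, is the next compound to be measured in this assay. It differs from compound 2 by amino in place of nitro on an aromatic carbon, an amino in place of nitro on an aromatic carbon. Because compound 2 gives only a limit, the direction and size of the step cannot be anchored to anything measured, and the expected step from compound 2 to compound 3 is written as an at least 1.6-fold lower number from compound 2 to compound 3 (0.20 log units; that floor lies within the scatter). Compound 3 is thus estimated to give about 25000 nM in this assay, within a range of 2000 nM to 150000 nM, with a real chance that it too is reported only as a limit.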

Compound 3, half-maximal inhibitory concentration: 19000 nM
Compound 3: the middle estimate sits 1.3-fold (0.12 log units) above what was measured; the range from low to high includes it.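

In this assay, among the compounds shown here, amino in place of nitro on an aromatic carbon of the shared core gives an at least 2.1-fold lower number from compound 2 to compound 3 (0.32 log units; beyond the scatter), the first step and one that lies beyond the scatter. This position is therefore one where a change of group registers on this read-out, and compound 3 gives 19000 nM, the first true number among the compounds shown. The step is only a floor and its full size stays unfixed, because compound 2 has no number of its own: the limit of > 40000 nM in this assay, at which 2 of the 3 values shown sit.

On these data alone, it remains open whether the change in this assay reflects the arrival of the amino group or the departure of the nitro group, a question that a plain hydrogen, a methoxy group or an acetamide at the same aromatic carbon would help to separate. As far as these compounds go, it is also open whether amino in place of nitro would give a readable step in the sulfonamide series of compound 1, which differs from compound 3 in more than one place and so cannot be compared with it here.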